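A few compounds are considered here, and "the series" means these few. Any claim that something is new, unique, unknown or untested is made for them only; others in the source may bear on it.

Compound 3 `CSc1nc2cccc(C(=O)O)c2n1Cc1ccc(-c2ccccc2-c2noc(O)n2)cc1` gives 100% in a functional assay on the whole organism for inhibition, with Rattus norvegicus as the target, with a stated time of 3 h, at a dose of 1 mg/kg by the oral route; a higher number here means more inhibition at the dose given (going by the name of the read-out), a lower number less inhibition. For the measured compounds named here, that is the largest of the three numbers measured so far, though the gaps differ in weight: compound 2 `COc1nc2cccc(C(=O)O)c2n1Cc1ccc(-c2ccccc2-c2noc(O)n2)cc1` gives 90%, and the step of a number 10 percentage points higher from compound 2 to compound 3 (within the scatter) stays within the usual scatter of such measurements, while compound 1 `CCc1nc2cccc(C(=O)O)c2n1Cc1ccc(-c2ccccc2-c2noc(O)n2)cc1` gives 88%, and the step of a number 12 percentage points higher from compound 1 to compound 3 (beyond the scatter) goes beyond it. The step of a number 2 percentage points higher from compound 1 to compound 2 (within the scatter) likewise stays within the scatter.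

Compound 4 `CCSc1nc2cccc(C(=O)O)c2n1Cc1ccc(-c2ccccc2-c2noc(O)n2)cc1` differs from compound 3 by methyl in place of hydrogen on a saturated chain carbon bound to a sulfur. Going by the values given here, none of the measured steps makes this same change; each of them swaps the whole group on the aromatic carbon rather than lengthening the chain on the sulfur, so they offer only a loose guide. Since compound 3 already sits at the top of the scale, there is little room for a higher number, and a drop beyond the scatter would need evidence that the measured steps do not supply. The expected step is therefore a number 4 percentage points lower from compound 3 to compound 4 (within the scatter), a change within the scatter. Compound 4 is estimated at 96%, within the range 86% to 100%.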

Compound 4, a percentage reported as inhibition, in the whole organism at one dose (the size of the read-out at that dose, not a potency): 83%
The estimate for compound 4 lay 13 percentage points above the measured number, and the stated range ends above it.
By their numbers in this assay, from the lowest: compounds 4, 1, 2 and 3 (each within the scatter of the next, the first and the last beyond it).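

The sulfur-bearing group at this aromatic carbon is sensitive to small changes: in this assay, extending methylsulfanyl to ethylsulfanyl gives a number 17 percentage points lower from compound 3 to compound 4 (beyond the scatter), so the result of compound 3 does not carry over to its closest homologue. The sulfur alone therefore does not secure the top number, since ethylsulfanyl gives a number 7 percentage points lower from compound 2 to compound 4 (within the scatter) and a number 5 percentage points lower from compound 1 to compound 4 (within the scatter), which leaves compound 4 indistinguishable from the methoxy and ethyl compounds. Nothing available explains the difference between methylsulfanyl and ethylsulfanyl.

The compounds shown leave open whether a longer chain on the sulfur, such as propylsulfanyl, or a branched one, such as isopropylsulfanyl, would give a lower number still or return towards that of compound 3. They also leave open how an amine at this aromatic carbon would compare.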